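Swapping cyanomethyl for vinyl in compound 3

A few compounds are considered here, and "the series" means these few. Any claim that something is new, unique, unknown or untested is made for them only; others in the source may bear on it.

In an ADME assay on L02 cells (Homo sapiens) for cytotoxicity, read by MTT assay, with a stated time of 48 h (a higher number here means a weaker inhibitor, a lower number a stronger inhibitor), compound 1 `CCn1c(C(=O)NCCCN(C)C)ccc1C(CC)(CC)c1ccc(OCC(O)C(C)(C)C)c(C)c1` gives 470 nM, while compound 2 `CCn1c(C(=O)N(C)CCC#N)ccc1C(CC)(CC)c1ccc(OCC(O)C(C)(C)C)c(C)c1` gives 14900 nM. Going by the values given here, compound 2 thus holds the higher of the two numbers measured so far. Among the compounds with values here, the only measured step is a 32-fold higher number from compound 1 to compound 2 (1.50 log units; beyond the scatter), a large one, in which (2-cyanoethyl)(methyl)amino took the place of (3-(dimethylamino)propyl)amino on a carbonyl carbon.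

Compound 3 `C=CCN(C)C(=O)c1ccc(C(CC)(CC)c2ccc(OCC(O)C(C)(C)C)c(C)c2)n1CC` differs from compound 2 in one small group: vinyl in place of cyanomethyl on a saturated chain carbon bound to an amide-type nitrogen. The same difference can also be read as 2-cyanoethyl to allyl.

The large measured step exchanged the entire group on the carbonyl carbon, whereas this change leaves the amide-type nitrogen and its methyl untouched, so that step is only a loose guide. Within the data shown here, no measured step covers this exchange itself. The expected change is therefore none beyond the scatter, with no firm direction. The expected step is a 1.2-fold lower number from compound 2 to compound 3 (0.09 log units; within the scatter). In this assay the estimate for compound 3 is 12000 nM, with an expected range from 5000 nM to 30000 nM.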

Compound 3, half-maximal inhibitory concentration: 6300 nM
Estimate against measurement, compound 3: 1.9-fold (0.28 log units) above, within the range that was stated.
By their numbers in this assay, from the lowest: compound 1; then compound 3; then compound 2.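

In this assay, the exchange of vinyl for cyanomethyl gives a 2.4-fold lower number from compound 2 to compound 3 (0.37 log units; beyond the scatter), so a change confined to the end of this chain, with the amide-type nitrogen and its methyl left in place, is enough to move the number beyond the scatter. That shift is still modest beside a 13-fold higher number from compound 1 to compound 3 (1.13 log units; beyond the scatter), which shows that replacing the whole group on the carbonyl carbon remains the much larger change, even with the nitrile gone from compound 3. Nothing measured here explains why the number moves in either step.

The compounds shown do not separate the parts of the larger change, since (3-(dimethylamino)propyl)amino and allyl(methyl)amino differ at once in the amide hydrogen, the chain and the terminal amine. As far as these compounds go, it also remains open how an ethyl, a hydroxymethyl or an aminomethyl group would compare with vinyl and cyanomethyl on a saturated chain carbon bound to an amide-type nitrogen, and whether a longer chain ending in a dimethylamino group would bring the number closer to that of compound 1.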